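Ester change on cyclohexyl core: from ethyl to hydroxy(phenyl)methyl

The compounds below may be only part of what the source reports. "The series", "measured", "known", "first", "only" and "open" are said of these compounds alone.

Going by the values given here, in a functional assay on MCF7 cells (Homo sapiens) for inhibition, read by MTT assay, with a stated time of 72 h (on this read-out higher numbers stand for weaker inhibition and lower numbers for stronger inhibition), compound 2 `CCC(=O)OC1(C(=O)Nc2ccc([N+](=O)[O-])cc2)CCCCC1` gives 14.1 nM, the lowest of the two numbers so far; compound 1 `O=C(/C=C/c1ccccc1)OC1(C(=O)Nc2ccc([N+](=O)[O-])cc2)CCCCC1` gives 57.6 nM. Compound 3 `O=C(OC1(C(=O)Nc2ccc([N+](=O)[O-])cc2)CCCCC1)C(O)c1ccccc1` differs from compound 2 by hydroxy(phenyl)methyl in place of ethyl on a carbonyl carbon. Among the compounds with values here, the one relevant step, a 4.1-fold lower number from compound 1 to compound 2 (0.61 log units; beyond the scatter), shows that removing a phenyl-bearing group raised potency; compound 3 brings a phenyl ring back, so a higher number, of roughly that size, is expected in this assay, namely a 2.8-fold higher number from compound 2 to compound 3 (0.45 log units; beyond the scatter). Compound 3 is therefore estimated at 40 nM, within 15 nM to 120 nM.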

Compound 3, half-maximal inhibitory concentration: 5.01 nM
Compound 3: middle estimate off by 8.0-fold (0.90 log units), on the high side; measured number outside the range, below it.
By their numbers in this assay, from the lowest: compound 3; then compound 2; then compound 1.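

Adding a phenyl ring at this place does not by itself raise the number in this assay: hydroxy(phenyl)methyl in place of ethyl gives a 2.8-fold lower number from compound 2 to compound 3 (0.45 log units; beyond the scatter), the opposite of what the first step suggested. Both groups in the second comparison carry a phenyl ring, yet hydroxy(phenyl)methyl in place of 2-phenylethenyl gives an 11-fold lower number from compound 1 to compound 3 (1.06 log units; beyond the scatter), so what carries the ring matters. No measurement here explains these differences.

Hydroxyl and phenyl enter together, so their separate contributions remain open. A benzyl or hydroxymethyl group on this carbonyl carbon would separate them.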